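Replacing the hydroxyphenylpropyl arm of compound 1 with a furanylmethyl

The source may hold more compounds than are shown below. What is called first, only, known or untested is meant among the compounds shown, and "the series" means these compounds.

Three compounds share one core and differ only in the group on the amine nitrogen. Compound 1 `OCCC(NC1CCN(CCCc2c[nH]c3ccc(-n4cnnc4)cc23)CC1)c1ccccc1` gives 5.1 nM in an assay on CHO cells for agonist activity at 5-hydroxytryptamine receptor 1D (Homo sapiens), read by GTPgammaS binding; a lower number here means that less compound is needed, a higher number that more compound is needed for the effect. Compound 2 `COC[C@H](NC1CCN(CCCc2c[nH]c3ccc(Cn4cncn4)cc23)CC1)c1ccc(F)cc1` gives 8.9 nM, and compound 3 `CC(=O)Nc1ccc([C@H](C)NCC2CCN(CCCc3c[nH]c4ccc(-n5cnnc5)cc34)CC2)cc1` gives 3 nM; the three values lie within the usual scatter of one another, so none of them can be told apart. Compound 4 `c1cc(CNC2CCN(CCCc3c[nH]c4ccc(-n5cnnc5)cc34)CC2)co1` has not been measured. It differs from compound 1 by (furan-3-yl)methyl in place of 3-hydroxy-1-phenylpropyl on an amine nitrogen. Going by the values given here, no measured pair shows this kind of exchange, so the step from compound 1 to compound 4 rests on judgement alone: a moderate rise is expected, a 2.9-fold higher number from compound 1 to compound 4 (0.47 log units; beyond the scatter), probably beyond the scatter. Compound 4 is estimated at 15 nM, within 4 nM to 60 nM.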

Compound 4, half-maximal effective concentration: 7.1 nM
Compound 4: middle estimate off by 2.1-fold (0.32 log units), on the high side; the range from low to high includes it.
By their numbers in this assay, from the lowest: compounds 3, 1, 4 and 2 (each within the scatter of the next, the first and the last beyond it).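

In this assay, the exchange on this amine nitrogen gives a 1.4-fold higher number from compound 1 to compound 4 (0.14 log units; within the scatter), the first single-place step available for this series. The 3-hydroxy-1-phenylpropyl group carries a hydrogen-bond donor and the (furan-3-yl)methyl group carries none, yet the two values cannot be told apart, so this position accepts both groups. No measurement shown explains why the number holds. As far as these compounds go, it remains open whether a plain methyl, a benzyl or a (thiophen-3-yl)methyl group on this nitrogen would also stay within the scatter of compound 1.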